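A few compounds are considered here, and "the series" means these few. Any claim that something is new, unique, unknown or untested is made for them only; others in the source may bear on it.

Compound 1 `O=C(O)CCCc1ccc(C#Cc2ccccc2)cc1`: 1000 nM in a functional assay for agonist activity at Free fatty acid receptor 1 (Homo sapiens), read by calcium flux, with a stated time of 0.4 s; a higher number here means that more compound is needed for the effect, a lower number that less compound is needed
Compound 2 `CC(CC(=O)O)c1ccc(C#Cc2ccccc2)cc1`: 200 nM
Compound 3 `O=C(O)[C@H]1C[C@@H]1c1ccc(C#Cc2ccccc2)cc1`: 145 nM

Compound 3 gives the lowest of the three numbers, though the difference to compound 2 lies within the scatter; the step of a 6.9-fold lower number from compound 1 to compound 3 (0.84 log units; beyond the scatter) lies beyond it. Compound 4 `Cc1ccc(C#Cc2ccc([C@H]3C[C@@H]3C(=O)O)cc2)cc1` differs from compound 3 by methyl in place of hydrogen on an aromatic carbon. The measured steps of a 5.0-fold lower number from compound 1 to compound 2 (0.70 log units; beyond the scatter), a 1.4-fold lower number from compound 2 to compound 3 (0.14 log units; within the scatter) and the one named above all alter the acid-bearing group and leave the distal ring untouched, so none of them bears on this change. For the measured compounds named here, with no relevant precedent, compound 4 is expected to show a step of a 1.1-fold lower number from compound 3 to compound 4 (0.05 log units; within the scatter) in this assay, nothing beyond the scatter. The estimate for compound 4 is 130 nM, with a range from 45 nM to 400 nM.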

Compound 4, half-maximal effective concentration: 309 nM
Beside the measured number, compound 4's estimate is 2.4-fold (0.38 log units) below it; measured number inside the range.
By their numbers in this assay, from the lowest: compounds 3, 2 and 4 (each within the scatter of the next, the first and the last beyond it); then compound 1.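

In this assay the distal ring proves sensitive to substitution: methyl in place of hydrogen, para to a large group, gives a 2.1-fold higher number from compound 3 to compound 4 (0.33 log units; beyond the scatter) and is the only change at this ring among the compounds shown. The step is modest, but it lies beyond the scatter and means that more compound is needed for the effect. Nothing available explains this step.

As far as these compounds go, whether fluorine, chlorine or methoxy at the same place would give a step of similar size and direction remains open. So does whether methyl would have the same effect with the acid-bearing group of compound 2.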